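The source may report more compounds than this note shows. Statements on the series, on what has been measured and on what is new or still open speak of the compounds shown alone.

Compound 1 `Cc1cc(C)cc(SCc2ccc(/C=C/C(=O)Nc3ccccc3N)cc2)c1`: 7.13%
Compound 2 `Nc1ccccc1NC(=O)/C=C/c1ccc(CSc2ccc(F)cc2)cc1`: 15.4%

Both compounds were tested in a functional assay on SMMC-7721 cells (Homo sapiens) for inhibition, read by CCK-8 assay, with a stated time of 72 h, tested at 8 uM; a lower number here means less inhibition of growth, a higher number more inhibition of growth at the concentration tested. Compound 2 stands within the scatter of compound 1, so these two values cannot be ranked. The next compound is compound 3 `CC(C)(C)c1ccc(SCc2ccc(/C=C/C(=O)Nc3ccccc3N)cc2)cc1`, in which tert-butyl takes the place of fluoro on an aromatic carbon, para to a large group: tert-butyl in place of fluoro on an aromatic carbon. For the measured compounds named here, only one measured step bears on this change: a number 8.3 percentage points higher from compound 1 to compound 2 (within the scatter), with 4-fluorophenyl in place of 3,5-dimethylphenyl on a sulfur. That step also altered the group on the sulfur, but it stayed small, and a single step gives no firm direction. No shift beyond the scatter is therefore expected in this assay. The expected step is a number 4.4 percentage points lower from compound 2 to compound 3 (within the scatter). For compound 3 the estimated value is 11%, with an expected range from 2% to 25%.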

Compound 3, percent growth inhibition at one concentration: 23.6%
Compound 3: middle estimate off by 12.6 percentage points, on the low side; low and high end bracket the measured number.
By their numbers in this assay, from the lowest: compounds 1, 2 and 3 (each within the scatter of the next, the first and the last beyond it).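

Placing tert-butyl on this aromatic carbon, four heavy atoms where fluoro had one, brings no change that can be read in this assay: the step is a number 8.2 percentage points higher from compound 2 to compound 3 (within the scatter) and so compound 2 and compound 3 cannot be ranked. The comparison with the 3,5-dimethylphenyl group on the sulfur gives the first difference in this set that clears the scatter, a number 16.5 percentage points higher from compound 1 to compound 3 (beyond the scatter) and this difference is modest. No measurement here accounts for either step.

From the compounds shown here alone, what an amine, a methoxy group or a carboxylic acid would give at this same place stays open. Going by these compounds, it is also open whether a longer chain, such as a hexyl group, would fit the same trend or break it.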